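The source may report more compounds than this note shows. Statements on the series, on what has been measured and on what is new or still open speak of the compounds shown alone.

Measured compounds:
compound 1 `CC1CCN(C2CCN(S(=O)(=O)c3ccccc3Br)CC2)CC1`: 3 nM
compound 2 `CC1CCN(C2CCN(S(=O)(=O)c3ccccc3-c3ccccc3)CC2)CC1`: 0.74 nM

Both were read in a functional assay on HT-29 cells (Homo sapiens) for antiproliferative activity, read by CellTiter-Glo, with a stated time of 72 h; a lower number here means a stronger inhibitor, a higher number a weaker inhibitor. For the measured compounds named here, compound 1 gives the higher of the two numbers; compound 2 sits at the other end, the only measured step being a 4.1-fold lower number from compound 1 to compound 2 (0.61 log units; beyond the scatter), a change on the aromatic ring attached to the sulfonyl sulfur.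

Compound 3 `Cc1nc(Cl)sc1S(=O)(=O)N1CCC(N2CCC(C)CC2)CC1` is not yet measured. Against compound 1 the change is 2-chloro-4-methyl-1,3-thiazol-5-yl in place of 2-bromophenyl on a sulfonyl sulfur. Going by the values given here, no measured step bears directly on this exchange: the step from compound 1 to compound 2 keeps the phenyl ring and alters only a substituent on it, whereas here the whole ring bound to the sulfonyl sulfur is replaced. The shared core is unchanged. Among the compounds with values here, with no comparable pair available, the working assumption is a number close to that of compound 1, with a wider uncertainty than usual.

Compound 3 is therefore expected to give 5 nM, within a range from 1.5 nM to 20 nM. The expected step is a 1.7-fold higher number from compound 1 to compound 3 (0.22 log units; within the scatter), which is within or near the scatter and is not to be read as a confident direction.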

Compound 3, half-maximal inhibitory concentration: 1.5 nM
Compound 3: middle estimate off by 3.3-fold (0.52 log units), on the high side; low and high end bracket the measured number.
By their numbers in this assay, from the lowest: compound 2; then compounds 3 and 1 (each within the scatter of the next).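

On the sulfonyl sulfur, the ring itself can be exchanged and not only its substituent: in this assay, 2-chloro-4-methyl-1,3-thiazol-5-yl in place of 2-bromophenyl gives a 2.0-fold lower number from compound 1 to compound 3 (0.30 log units; within the scatter). Compound 3 and compound 1 are therefore not separated by this read-out, so low-nanomolar antiproliferative activity in this small set does not depend on a six-membered aromatic ring of carbon only at this place. Nothing available explains this result or links it to any property of either group.

On these data alone, it remains open whether phenyl in place of chloro on the thiazole would repeat a 4.1-fold lower number from compound 1 to compound 2 (0.61 log units; beyond the scatter). Also open, as far as these compounds go, is how a pyridyl ring, or a carboxylic acid on the ring bound to the sulfonyl sulfur, would read in this assay.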